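A few compounds are considered here, and "the series" means these few. Any claim that something is new, unique, unknown or untested is made for them only; others in the source may bear on it.

Of the compounds shown here, two of a shared core have been measured in an assay on isolated protein for inhibition of P2X purinoceptor 7 (Homo sapiens); a higher number here means a weaker inhibitor, a lower number a stronger inhibitor. Compound 1 `CC(C)CN1C(=O)CC[C@H]1C(=O)NCc1ccc(F)cc1Cl` carries an isobutyl group on the amide-type nitrogen in the ring, and in this assay compound 1 gives 398 nM. Compound 2 `O=C(NCc1ccc(F)cc1Cl)[C@@H]1CCC(=O)N1C1CCC1` carries a cyclobutyl group in that place, and in this assay compound 2 gives 25.1 nM. Among the compounds with values here, the one step between them, a 16-fold lower number from compound 1 to compound 2 (1.20 log units; beyond the scatter), is the only step on record. Among the two numbers compound 2 stands at the lower one, with compound 1 the only neighbour.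

Compound 3 `O=C(NCc1ccc(F)cc1Cl)[C@@H]1CCC(=O)N1C1CCCC1` is the next step from compound 2: cyclopentyl in place of cyclobutyl on an amide-type nitrogen in a ring. The step from compound 1 to compound 2 bears on it only loosely, since it exchanged a branched chain for a ring, whereas here one ring of carbon is exchanged for a ring of carbon that is larger by one atom. Within the data shown here, no measured step covers such a change, so the expectation rests on the single large step already seen and on the likeness of the two rings. Compound 3 is therefore expected to give roughly 20 nM in this assay, estimated to lie between 6 nM and 70 nM, which means an expected step of a 1.3-fold lower number from compound 2 to compound 3 (0.10 log units; within the scatter), not beyond the scatter.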

Compound 3, half-maximal inhibitory concentration: 501 nM
Compound 3: the middle estimate sits 25-fold (1.40 log units) below what was measured, outside the stated range (above it).
By their numbers in this assay, from the lowest: compound 2; then compounds 1 and 3 (each within the scatter of the next).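

In this assay, the change from a four-membered to a five-membered ring of carbon on the amide-type nitrogen is far from neutral, giving a 20-fold higher number from compound 2 to compound 3 (1.30 log units; beyond the scatter), so the earlier gain with cyclobutyl cannot be read as a benefit of having any carbon ring at this position. Cyclopentyl and isobutyl cannot be told apart here, with a 1.3-fold higher number from compound 1 to compound 3 (0.10 log units; within the scatter), which leaves cyclobutyl as the only one of the three groups whose steps to both others lie beyond the scatter, and this makes the position sensitive to the exact group rather than to the mere presence of a ring or a branch. Nothing at hand accounts for this sharp difference between two such similar rings.

The compounds shown leave open whether cyclobutyl marks a narrow optimum, since neither cyclopropyl nor cyclohexyl on this nitrogen appears among them, and a shorter chain such as ethyl is equally untested here. They also leave open whether the same gap between cyclobutyl and cyclopentyl would hold if a pyridylmethyl group replaced the chlorofluorobenzyl group on the other amide of the shared core.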